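Sulfonyl Aryl Swap in a Tracheal Antagonist Series

The source may hold more compounds than are shown below. What is called first, only, known or untested is meant among the compounds shown, and "the series" means these compounds.

Measured compounds:
Compound 1 `COc1cc(C(=O)NS(=O)(=O)c2cccs2)ccc1Cn1ccc2ccc(NC(=O)CC3CCCC3)cc21`: 9.6
Compound 2 `COc1cc(C(=O)NS(=O)(=O)c2ccc3ccccc3c2)ccc1Cn1ccc2ccc(NC(=O)CC3CCCC3)cc21`: 8.3

Compound 2 holds the lower of the two numbers in a functional assay (trachea) for antagonist activity, with Cavia porcellus as the target; a lower number here means a less potent compound, a higher number a more potent compound, by a factor of ten per unit of this negative logarithm; the two are separated by the step of a number 1.30 log units lower from compound 1 to compound 2 (beyond the scatter). Compound 3 `COc1cc(C(=O)NS(=O)(=O)c2ccccc2N)ccc1Cn1ccc2ccc(NC(=O)CC3CCCC3)cc21` is not yet measured and differs from compound 2 by 2-aminophenyl in place of naphthalen-2-yl on a sulfonyl sulfur. Among the measured compounds shown here, the only measured step at this position is the one from compound 1 to compound 2, and it was large; compound 3 again carries a single aromatic ring at this position, as compound 1 does. Compound 3 is therefore expected to recover part of that loss, a number 0.70 log units higher from compound 2 to compound 3 (beyond the scatter). The estimate for compound 3 is 9, ranging from 8.3 to 9.7.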

Compound 3, negative logarithm of the antagonist equilibrium constant: 9.9
Estimate against measurement, compound 3: 0.90 log units below, outside the stated range (above it).
By their numbers in this assay, from the lowest: compound 2; then compounds 1 and 3 (each within the scatter of the next).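

In this assay, the step of a number 1.60 log units higher from compound 2 to compound 3 (beyond the scatter) is larger than the loss seen on going to naphthalen-2-yl, so that loss is not a general feature of changing the aryl group on the sulfonyl sulfur. Among these three compounds naphthalen-2-yl stands alone, while the two single-ring groups differ only by a number 0.30 log units higher from compound 1 to compound 3 (within the scatter). Nothing available explains why the two-ring group gives the lower number.

Open, on these data alone, is what a plain phenyl or a 2-hydroxyphenyl on the sulfonyl sulfur would give, and so whether the amine of 2-aminophenyl contributes at all.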